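Adding Fluorine to a Second Core: Expected Clearance

The source may report more compounds than this note shows. Statements on the series, on what has been measured and on what is new or still open speak of the compounds shown alone.

Compound 1 `O=C1[C@@H](NS(=O)(=O)c2ccc3cc(Cl)ccc3c2)CCN1c1ccc2c(c1)CCNC2` and compound 3 `O=C1[C@@H](NS(=O)(=O)c2ccc3cc(Cl)ccc3c2)CCN1c1cc2c(cc1F)CNCC2` share one core and differ by a single change, (fluoro in place of hydrogen on an aromatic carbon). In an in vivo ADME assay on the whole organism (plasma, strain Sprague-Dawley) for pharmacokinetics, with Rattus norvegicus as the target (a lower number here means slower removal, a higher number faster removal of the compound), compound 1 gives 4 mL/min/kg and compound 3 gives 1.7 mL/min/kg; the step between them is a 2.4-fold lower number from compound 1 to compound 3 (0.37 log units; beyond the scatter). Compound 2 `O=C1[C@@H](NS(=O)(=O)c2ccc3c(Cl)c[nH]c3c2)CCN1c1ccc2c(c1)CCNC2` is built on a different core; the difference between the two cores is not broken down here. In this assay compound 2 gives 7.7 mL/min/kg. Compound 4 `O=C1[C@@H](NS(=O)(=O)c2ccc3c(Cl)c[nH]c3c2)CCN1c1cc2c(cc1F)CNCC2` is derived from compound 2 by the same change, (fluoro in place of hydrogen on an aromatic carbon), at the same kind of place. Because the earlier step of a 2.4-fold lower number from compound 1 to compound 3 (0.37 log units; beyond the scatter) was modest, the step from compound 2 to compound 4 is expected to be of similar size, a 2.4-fold lower number from compound 2 to compound 4 (0.38 log units; beyond the scatter), though it rests on a single measured pair. Compound 4 is therefore expected to give about 3.2 mL/min/kg, most likely between 1.5 mL/min/kg and 7 mL/min/kg.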

Compound 4, clearance: 1.3 mL/min/kg
For compound 4 the middle estimate is 2.5-fold (0.39 log units) above the measured one; measured number outside the range, below it.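

In this assay, the same fluoro change also lowers the number on the second core, giving a 5.9-fold lower number from compound 2 to compound 4 (0.77 log units; beyond the scatter). Both steps point the same way, and their sizes cannot be told apart: the same change on two cores in this assay, a 2.4-fold lower number (0.37 log units; beyond the scatter) from compound 1 to compound 3 and a 5.9-fold lower number (0.77 log units; beyond the scatter) from compound 2 to compound 4, 2.5-fold (0.40 log units) apart, within the scatter of two such steps. The change therefore carried over from one core to the other in direction and, within the scatter, in size, but two pairs do not show that it would do so on any further core, and they do not explain why clearance falls.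

The compounds shown carry only hydrogen or fluoro at this place, so the effect of a methyl, methoxy or nitrile group there remains open. Also open, going by these compounds, is whether fluoro on a different carbon of this ring would give a similar step.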